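Working notes: from compound 2 to compound 3

A few compounds are considered here, and "the series" means these few. Any claim that something is new, unique, unknown or untested is made for them only; others in the source may bear on it.

Measured values in a functional assay on HCT-116 cells (Homo sapiens) for cytotoxicity, read by MTT assay, with a stated time of 72 h (on this read-out lower numbers stand for stronger inhibition and higher numbers for weaker inhibition), are as follows.
- compound 1 `Cc1c(/N=C/c2cccc(O)c2)c(=O)n(-c2ccccc2)n1C` gives 617000000 nM
- compound 2 `Cc1c(/N=C/c2ccccc2)c(=O)n(-c2ccccc2)n1C` gives 589000000 nM

For the measured compounds named here, compound 2 and compound 1 give numbers that cannot be told apart in this assay: the only measured step, a 1.0-fold lower number from compound 1 to compound 2 (0.02 log units; within the scatter), falls within the scatter, so compound 2 stands level with its sole neighbour rather than apart from it.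

Compound 3 `Cc1c(/N=C/c2ccc(Cl)cc2)c(=O)n(-c2ccccc2)n1C` differs from compound 2 by chloro in place of hydrogen on an aromatic carbon. Going by the values given here, no measured step touches a chloro substituent; the one step available concerns the hydroxy group on the same ring and changed nothing beyond the scatter. Both measured compounds sit at very weak inhibition in this assay, and nothing in the data suggests that this position on the six-membered ring moves the read-out. The expectation for compound 3 is therefore a step in this assay of a 1.1-fold lower number from compound 2 to compound 3 (0.02 log units; within the scatter), that is, none beyond the scatter. The estimate for compound 3 in this assay is 560000000 nM, with a range from 250000000 nM to 1250000000 nM.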

Compound 3, half-maximal inhibitory concentration: 589000000 nM
For compound 3 the middle estimate is 1.1-fold (0.02 log units) below the measured one; measured number inside the range.
By their numbers in this assay, from the lowest: compounds 2, 3 and 1 (each within the scatter of the next).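

In this assay, for the compounds shown here, chloro in place of hydrogen on an aromatic carbon, para to a large group, gives no change at the digits printed from compound 2 to compound 3 (within the scatter) and so provides the first reading at this position and the first for a halogen on this ring. The wider change, 4-chlorophenyl in place of 3-hydroxyphenyl, gives a 1.0-fold lower number from compound 1 to compound 3 (0.02 log units; within the scatter) in the same assay, so moving from the hydroxy compound to the chloro compound alters both the group and its place on the ring without a shift beyond the scatter. Compound 1, compound 2 and compound 3 therefore stand level at very weak inhibition, and this flat reading now covers hydrogen, hydroxy and chloro on this ring. No supporting measurement bears on this result.

The compounds shown leave open whether an amine, a carboxylic acid or a longer chain such as butoxy at this same place would bring the number away from this level. They also leave open whether any change to the shared core, including its phenyl group on nitrogen, would move the read-out, as all three compounds keep that part unchanged.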